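A few compounds are considered here, and "the series" means these few. Any claim that something is new, unique, unknown or untested is made for them only; others in the source may bear on it.

Compound 1 `O=C(CSc1ccccc1)N1N=C(c2cc3ccccc3oc2=O)C[C@@H]1c1ccccc1`: 20300 nM
Compound 2 `O=C(CSCc1ccco1)N1N=C(c2cc3ccccc3oc2=O)C[C@@H]1c1ccccc1C(F)(F)F`: 10300 nM
Compound 3 `O=C(CSc1ccc(Br)cc1)N1N=C(c2cc3ccccc3oc2=O)C[C@@H]1c1ccccc1C(F)(F)F`: 14700 nM

Not yet measured: compound 4 `CCCCSCC(=O)N1N=C(c2cc3ccccc3oc2=O)C[C@@H]1c1ccccc1`.

In a functional assay on SGC-7901 cells (Homo sapiens) for cytotoxicity, read by MTT assay, with a stated time of 48 h (a higher number here means a weaker inhibitor, a lower number a stronger inhibitor), compound 1 stands within the scatter of both compound 2 and compound 3, so the three measured compounds cannot be ranked on these numbers. The change that leads to compound 4 is butyl in place of phenyl on a sulfur, which puts butyl in place of phenyl on a sulfur.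

Among the compounds with values here, only one measured step bears on this place: a 1.4-fold higher number from compound 2 to compound 3 (0.15 log units; within the scatter), with 4-bromophenyl in place of (furan-2-yl)methyl on a sulfur. That step stays within the scatter. Within the data shown here, it is also indirect evidence, as compound 2 and compound 3 carry a trifluoromethyl group that compound 1 and compound 4 lack, and no measured compound has a butyl group on the sulfur. Even so, the one exchange seen at the sulfur left this assay unmoved beyond the scatter, so no step beyond the scatter is expected here either. The estimated step is a 1.3-fold lower number from compound 1 to compound 4 (0.10 log units; within the scatter), which is a small one.

For compound 4 the expected value is 16000 nM, with an estimated range from 7500 nM to 34000 nM.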

Compound 4, half-maximal inhibitory concentration: 7300 nM
For compound 4 the middle estimate is 2.2-fold (0.34 log units) above the measured one; measured number outside the range, below it.
By their numbers in this assay, from the lowest: compounds 4, 2, 3 and 1 (each within the scatter of the next, the first and the last beyond it).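

In this assay, within the data shown here, butyl in place of phenyl on the sulfur gives a 2.8-fold lower number from compound 1 to compound 4 (0.44 log units; beyond the scatter), the first exchange at this position to lie beyond the scatter, whereas the only earlier one, a 1.4-fold higher number from compound 2 to compound 3 (0.15 log units; within the scatter), stayed within it. The group on the sulfur therefore can move the number in this assay, at least in a compound without the trifluoromethyl group carried by compound 2 and compound 3, and here the open-chain group gives the lower number of the pair. This rests on a single pair and the step is modest, and nothing measured here accounts for it.

The compounds shown leave open whether the step follows from the loss of the aromatic ring or from the butyl chain itself, a question that a cyclohexyl group, a benzyl group or a longer chain such as hexyl on the sulfur could help to settle. They also leave open whether butyl gives a similar step in a compound that carries the trifluoromethyl group, since no pair shown tests the sulfur exchange and that group together.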